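The source may hold more compounds than are shown below. What is called first, only, known or untested is meant among the compounds shown, and "the series" means these compounds.

Working notes on the oxime series. Compound 1 `O/N=C(\CCN1CCN(c2ccccn2)CC1)c1ccc(F)cc1F`, compound 2 `N#Cc1cccnc1N1CCN(CC/C(=N\O)c2ccccc2)CC1` and compound 3 `CCO/N=C(\CCN1CCN(c2ccccc2C#N)CC1)c1ccccc1` have been run in a functional assay on HEK293 cells with D(4) dopamine receptor (Homo sapiens) as the target, read by FLIPR; a higher number here means that more compound is needed for the effect, a lower number that less compound is needed. In this assay compound 1 gives 8.9 nM, compound 2 gives 18 nM, and compound 3 gives 48.7 nM. Compound 3 thus carries the highest number of the three; its gap to compound 2 and its wider gap to compound 1 both lie beyond the scatter. No two of these three compounds differ in a single place, so no isolated step can be read from them.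

Compound 4 `CCO/N=C(\CCN1CCN(c2cccc(OCC)c2)CC1)c1ccccc1` is the next member, not yet measured in this assay. Relative to compound 3 it changes in one place: 3-ethoxyphenyl in place of 2-cyanophenyl on an amine nitrogen in a ring. Among the compounds with values here, no measured step of this kind exists, so the expectation rests on the change alone. The expected step in this assay is a 1.4-fold higher number from compound 3 to compound 4 (0.16 log units; within the scatter), with a modest rise thought somewhat more likely than a fall, though a result within the scatter would not surprise. Compound 4 is accordingly estimated at 70 nM, within a range from 18 nM to 280 nM.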

Compound 4, half-maximal effective concentration: 347 nM
Compound 4: middle estimate off by 5.0-fold (0.70 log units), on the low side, and the stated range ends below it.
By their numbers in this assay, from the lowest: compound 1; then compound 2; then compound 3; then compound 4.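

Within the data shown here, this is the first isolated step, and it falls on the aryl group on the ring amine nitrogen: in this assay, 3-ethoxyphenyl in place of 2-cyanophenyl gives a 7.1-fold higher number from compound 3 to compound 4 (0.85 log units; beyond the scatter). The position is therefore not indifferent to its aryl group, as this one exchange, with the rest of the molecule unchanged, moves the number beyond the scatter. No measurement at hand bears on why the step has this size.

Loss of the nitrile, arrival of the ethoxy and the change of substituent position all travel together in this exchange, so their shares remain unresolved; a plain phenyl or a methoxyphenyl on that nitrogen would help separate them. From the compounds shown here alone, whether the step holds with the free oxime of compound 1 and compound 2 also stays open.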